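The source may hold more compounds than are shown below. What is called first, only, known or untested is meant among the compounds shown, and "the series" means these compounds.

Measured compounds:
compound 1 `Fc1ccc2nc(-c3cnccn3)n(C3CC3)c2c1`: 541 nM
compound 2 `Fc1ccc2nc(-c3ccnnc3)n(C3CC3)c2c1`: 330 nM
compound 3 `CC(C)c1ncncc1-c1nc2cc(F)c(F)cc2n1C1CC1`: 5 nM

In an assay on cells for inhibition of cytochrome P450 11B2, mitochondrial (Homo sapiens), read by HPLC, with a stated time of 90 min (on this read-out higher numbers stand for weaker inhibition and lower numbers for stronger inhibition), compound 3 gives the lowest number of the three, and its gaps to compound 2 and to compound 1 both lie beyond the usual scatter, so it is the strongest inhibitor here. Among the compounds with values here, the only one-place step among the measured compounds, a 1.6-fold lower number from compound 1 to compound 2 (0.21 log units; within the scatter), swaps one ring for another and says nothing about the change now in question.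

Compound 4 `CC(F)(F)c1ncncc1-c1nc2cc(F)c(F)cc2n1C1CC1` differs from compound 3 only in this: 1,1-difluoroethyl in place of isopropyl on an aromatic carbon. Within the data shown here, no measured step bears on such an exchange, so no step beyond the scatter is expected, and the estimated step is a 1.2-fold higher number from compound 3 to compound 4 (0.08 log units; within the scatter). Compound 4 is therefore expected to give about 6 nM, between 2 nM and 20 nM.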

Compound 4, half-maximal inhibitory concentration: 50 nM
Estimate against measurement, compound 4: 8.3-fold (0.92 log units) below; the measured number lies above the stated range.
By their numbers in this assay, from the lowest: compound 3; then compound 4; then compounds 2 and 1 (each within the scatter of the next).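

With 1,1-difluoroethyl in place of isopropyl on this aromatic carbon, next to the ring nitrogen, this assay shows a 10-fold higher number from compound 3 to compound 4 (1.00 log units; beyond the scatter). So this place is sensitive to the exchange, and inhibition clearly weakens, which the earlier ring swap could not reveal. Nothing measured here explains this loss. Still open, going by these compounds, is whether an ethyl group, a cyclopropyl group or an amine at this place would match compound 3 or fall further. On these data alone, it is also open whether the same exchange would weaken inhibition on a different core.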